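A few compounds are considered here, and "the series" means these few. Any claim that something is new, unique, unknown or untested is made for them only; others in the source may bear on it.

Within the data shown here, the three compounds measured so far share one core. Compound 1 `Cc1ccc2nc(Nc3nc(Nc4ccc(S(C)(=O)=O)cc4)ncc3F)sc2c1` gives 9180 nM in a functional assay on HCT-116 cells (Homo sapiens) for antiproliferative activity, read by MTT assay, with a stated time of 48 h; on this read-out higher numbers stand for weaker inhibition and lower numbers for stronger inhibition. Compound 2 `Cc1ccc2nc(Nc3ccnc(Nc4ccc(S(C)(=O)=O)cc4)n3)sc2c1` gives 1750 nM in this assay, and compound 3 `Cc1ccc2nc(Nc3ccnc(Nc4ccc(S(N)(=O)=O)cc4)n3)sc2c1` gives 900 nM in this assay. Compound 2 thus stands second highest of the three numbers: its nearest neighbour is compound 3, with a 1.9-fold lower number from compound 2 to compound 3 (0.29 log units; within the scatter), a gap within the scatter, and its furthest is compound 1, with a 5.2-fold lower number from compound 1 to compound 2 (0.72 log units; beyond the scatter).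

Compound 4 `COc1ccc2nc(Nc3ccnc(Nc4ccc(S(C)(=O)=O)cc4)n3)sc2c1` differs from compound 2 by methoxy in place of methyl on an aromatic carbon. Neither measured step touches this part of the molecule: a 5.2-fold lower number from compound 1 to compound 2 (0.72 log units; beyond the scatter) concerns a fluoro on an aromatic carbon of the other ring, and a 1.9-fold lower number from compound 2 to compound 3 (0.29 log units; within the scatter) concerns an amino on a sulfonyl sulfur. Among the measured compounds shown here, the data give no direct guide to what a methoxy at this place does, and the only change that moved the number beyond the scatter lay elsewhere. The step from compound 2 to compound 4 in this assay is therefore expected to be small, a 1.2-fold lower number from compound 2 to compound 4 (0.07 log units; within the scatter), and not beyond the scatter in either direction. Compound 4 is estimated at 1500 nM, within a range of 500 nM to 4500 nM.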

Compound 4, half-maximal inhibitory concentration: 2270 nM
Estimate against measurement, compound 4: 1.5-fold (0.18 log units) below, within the range that was stated.
By their numbers in this assay, from the lowest: compounds 3, 2 and 4 (each within the scatter of the next, the first and the last beyond it); then compound 1.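

Among these compounds, compound 4 gives the first reading at this place, an aromatic carbon of the six-membered aromatic ring of carbon only within the fused system, which neither earlier step touched. In this assay the change shows a 1.3-fold higher number from compound 2 to compound 4 (0.11 log units; within the scatter) so this exchange does not separate the two compounds, even though the entering methoxy brings 2 heavy atoms and 1 hydrogen-bond acceptor where the leaving methyl has 1 heavy atom and 0 hydrogen-bond acceptors. Nothing available bears on why the number stays within the scatter here.

The compounds shown give only methyl and methoxy at this carbon, so it stays open whether an amine, a carboxylic acid, a chloro group or a longer chain such as ethoxy would move the number beyond the scatter in either direction. On these data alone, it also stays open whether methoxy at this place would behave the same way on the core of compound 3, which has amino on the sulfonyl sulfur, or on the core of compound 1, which has the fluoro group.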